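A few compounds are considered here, and "the series" means these few. Any claim that something is new, unique, unknown or untested is made for them only; others in the source may bear on it.

Compound 1 `COC(=O)CNC(=O)c1ccc(OC[C@@H]2COc3ccccc3O2)cc1-c1ccccc1C` is the reference point of this small set; in a functional assay (HSMC cells, Homo sapiens) for antiproliferative activity, with a stated time of 72 h (a lower number here means a stronger inhibitor, a higher number a weaker inhibitor), compound 1 gives 700 nM. Compound 2 `COC(=O)[C@H](CC(C)C)NC(=O)c1ccc(OC[C@@H]2COc3ccccc3O2)cc1-c1ccccc1C` differs from it in a single place: isobutyl in place of hydrogen on a saturated chain carbon bound to an amide-type nitrogen and a carbonyl carbon. That change carried a step of a 7.4-fold higher number from compound 1 to compound 2 (0.87 log units; beyond the scatter).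

Compound 3 `COC(=O)CNC(=O)c1ccc(C(=O)NC[C@H]2COc3ccccc3O2)cc1-c1ccccc1C` carries a different core, and how the core of compound 3 differs from the core of compound 1 is not broken down here. In this assay compound 3 gives 113000 nM, the highest of the three measured numbers. For comparison, compound 2 gives 5200 nM, so compound 3 sits well beyond the scatter above both earlier compounds.

Compound 4 `COC(=O)[C@H](CC(C)C)NC(=O)c1ccc(C(=O)NC[C@H]2COc3ccccc3O2)cc1-c1ccccc1C` has not yet been measured. It differs from compound 3 in one place: isobutyl in place of hydrogen on a saturated chain carbon bound to an amide-type nitrogen and a carbonyl carbon. This is the same change as the one made from compound 1 to compound 2, at the same place, and among the compounds shown it occurs twice in all. Because that earlier change gave a 7.4-fold higher number from compound 1 to compound 2 (0.87 log units; beyond the scatter), a step of about the same size is expected here, namely a 5.3-fold higher number from compound 3 to compound 4 (0.73 log units; beyond the scatter). The estimate rests on a single prior step and a different core, so it is held loosely. Compound 4 is expected to give roughly 600000 nM, with the likely range running from 150000 nM to 2000000 nM. Given how high the starting number already is, the measurement may well come back as a limit rather than a number.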

Compound 4, half-maximal inhibitory concentration: 103000 nM
The estimate for compound 4 lay 5.8-fold (0.77 log units) above the measured number; measured number below the stated range.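

In this assay the isobutyl group in place of hydrogen did not carry a single effect from one core to the other: it gave a 7.4-fold higher number from compound 1 to compound 2 (0.87 log units; beyond the scatter) on the first core, while on the second it gave a 1.1-fold lower number from compound 3 to compound 4 (0.04 log units; within the scatter). The two steps therefore cannot be treated as one transferable increment, and a size read on one core did not hold on the other in this series: the same change on two cores in this assay, a 7.4-fold higher number (0.87 log units; beyond the scatter) from compound 1 to compound 2 and a 1.1-fold lower number (0.04 log units; within the scatter) from compound 3 to compound 4, 8.1-fold (0.91 log units) apart, beyond the scatter of two such steps
Going by these compounds alone, this shows that the outcome of this change depends on the core it is made on, but with only one pair on each core it does not show what in the cores is responsible, nor does the step that stays within the scatter show that isobutyl would be without consequence on any further core.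

The compounds shown leave open whether a methyl or a benzyl group on the same saturated chain carbon would follow the same split between the two cores. They also leave open how a carboxylic acid in place of the methoxycarbonyl group would read on either core.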